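Series notes: acid head-group swap on the fused bicyclic core

The compounds below may be only part of what the source reports. "The series", "measured", "known", "first", "only" and "open" are said of these compounds alone.

Measured so far:
compound 1 `O=C(O)c1csc([C@H]2CC[C@@H]3[C@@H](/C=C/CCCOc4ccccc4)[C@H](O)C[C@@H]3O2)n1` — 13 nM
compound 2 `O=C(O)c1csc([C@H]2CC[C@@H]3[C@@H](/C=C/[C@@H](O)COc4ccccc4)[C@H](O)C[C@@H]3O2)n1` — 7.9 nM

Among the measured compounds shown here, in a functional assay on CHO cells for agonist activity at prostaglandin E2 receptor EP2 subtype (Homo sapiens), read by HTRF and cAMP accumulation, with a stated time of 30 min (on this read-out higher numbers stand for an effect only at larger amounts of compound and lower numbers for an effect already at smaller amounts), compound 2 gives 7.9 nM, the lowest of the two numbers; the only step available, a 1.6-fold lower number from compound 1 to compound 2 (0.22 log units; within the scatter), is within the scatter. Compound 3 `O=C(O)CCC[C@H]1CC[C@@H]2[C@@H](/C=C/[C@@H](O)COc3ccccc3)[C@H](O)C[C@@H]2O1` carries 3-carboxypropyl in place of 4-carboxy-1,3-thiazol-2-yl on a saturated ring carbon. For the measured compounds named here, no measured step touches this position; the step from compound 1 to compound 2 concerns the chain at the double bond only, so it gives no guidance. The size of a 3.8-fold higher number from compound 2 to compound 3 (0.58 log units; beyond the scatter) is therefore expected with low confidence, with no direction preferred beyond the scatter. Compound 3 is estimated at 30 nM, range 5 nM to 200 nM.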

Compound 3, half-maximal effective concentration: 8900 nM
Estimate against measurement, compound 3: 300-fold (2.47 log units) below; measured number outside the range, above it.
By their numbers in this assay, from the lowest: compounds 2 and 1 (each within the scatter of the next); then compound 3.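

In this assay, the group on the saturated ring carbon next to the ring oxygen proves decisive: 3-carboxypropyl in place of 4-carboxy-1,3-thiazol-2-yl gives a 1100-fold higher number from compound 2 to compound 3 (3.05 log units; beyond the scatter), whereas the earlier change in the chain at the double bond stayed within the scatter. A carboxylic acid is present on both sides of this step, so its presence alone does not keep the number of compound 2. Nothing measured here explains the size of this step.

From the compounds shown here alone, it remains open whether the ring or the spacing of the carboxylic acid from the core accounts for the step. A 4-carboxyphenyl group at this position, or a tetrazole in place of the carboxylic acid on the thiazole ring, could begin to separate the two.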